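Removing One Chloro from a Fused Bicyclic Core

The source may hold more compounds than are shown below. What is called first, only, known or untested is meant among the compounds shown, and "the series" means these compounds.

Of the compounds shown here, three have been measured in a functional assay on HOP-62 cells (Homo sapiens) for cytotoxicity, read by sulforhodamine B assay, with a stated time of 48 h; a lower number here means that less compound is tolerated, a higher number that more compound is tolerated. Compound 1 `ClCc1cccc(Cn2cnc3c(Cl)ncnc32)c1` gives 10200 nM in this assay. Compound 3 `ClCc1cccc(Cn2cnc3c(Cl)nc(Cl)nc32)c1` gives 8310 nM in this assay. Compound 3 and compound 1 differ by hydrogen in place of chloro on an aromatic carbon. The step this made in this assay was a 1.2-fold higher number from compound 3 to compound 1 (0.09 log units; within the scatter). Compound 2 `ClCc1ccc(Cn2cnc3nc(Cl)nc(Cl)c32)cc1` gives 7940 nM in this assay; the difference between its core and the core of compound 3 is not broken down here, and the two values lie within the scatter of each other.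

Compound 4 `ClCc1ccc(Cn2cnc3ncnc(Cl)c32)cc1` has not yet been measured in this assay. It differs from compound 2 by hydrogen in place of chloro on an aromatic carbon. This is the same change as the one between compound 3 and compound 1, and it occurs twice among the compounds shown. Among the compounds with values here, only one earlier step informs the expectation, and it was small, because a 1.2-fold higher number from compound 3 to compound 1 (0.09 log units; within the scatter) stayed within the scatter. Compound 4 is therefore expected to give about 9500 nM in this assay, estimated to fall between 4500 nM and 20000 nM. This estimate means an expected step of a 1.2-fold higher number from compound 2 to compound 4 (0.08 log units; within the scatter), beside the earlier one.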

Compound 4, concentration lethal to 50% of the cells: 5620 nM
The estimate for compound 4 lay 1.7-fold (0.23 log units) above the measured number, within the range that was stated.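

In this assay, hydrogen in place of the chloro between two ring nitrogen atoms gave a 1.4-fold lower number from compound 2 to compound 4 (0.15 log units; within the scatter). Set beside the same change on the other core, this step does not differ from the earlier one beyond what repeated measurement would give: the same change on two cores in this assay, a 1.2-fold higher number (0.09 log units; within the scatter) from compound 3 to compound 1 and a 1.4-fold lower number (0.15 log units; within the scatter) from compound 2 to compound 4, 1.7-fold (0.24 log units) apart, within the scatter of two such steps. This shows only that, on these two cores, the exchange of chloro for hydrogen left the number within the scatter each time; it does not show that the same would hold on any other core, and two steps this small fix no direction for the change.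

The compounds shown carry only chloro or hydrogen at this place on the core, so the outcome with an amine, a methoxy group or a longer chain there remains open. As far as these compounds go, all four also carry the chloromethyl group, and whether the numbers in this assay would hold with a hydroxymethyl or a plain methyl group in its stead is equally open.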